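The source may hold more compounds than are shown below. What is called first, only, known or untested is meant among the compounds shown, and "the series" means these compounds.

Measured so far in a functional assay on HCT-116 cells (Homo sapiens) for antiproliferative activity, read by MTT assay, with a stated time of 48 h; on this read-out higher numbers stand for weaker inhibition and lower numbers for stronger inhibition:
compound 1 `COc1ccc(CN(C(=O)CSc2nc3ccccc3s2)c2cc(OC)c(OC)c(OC)c2)cc1C` — 17100 nM
compound 2 `COc1cc(N(Cc2ccc(Cl)cc2)C(=O)CSc2nc3ccccc3s2)cc(OC)c1OC` — 603000 nM

Compound 1 holds the lowest of the two numbers; its nearest neighbour is compound 2, reached by a 35-fold higher number from compound 1 to compound 2 (1.55 log units; beyond the scatter), a large step tied to 4-chlorophenyl in place of 4-methoxy-3-methylphenyl on a saturated chain carbon bound to an amide-type nitrogen.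

Compound 3 `COc1ccc(CN(C(=O)CSc2nc3ccccc3s2)c2cc(OC)c(OC)c(OC)c2)cc1Br` is not yet measured. It differs from compound 1 by bromo in place of methyl on an aromatic carbon, that is 4-methoxy-3-methylbenzyl to 3-bromo-4-methoxybenzyl, with the methoxy group retained. Among the compounds with values here, the only measured step, from compound 1 to compound 2, swaps the whole aryl pattern and so bears on this change only loosely; no step isolates a single substituent on that ring. The expectation in this assay is therefore a step of no more than modest size, most likely within the scatter, with a slight lean toward a higher number. The estimated step from compound 1 to compound 3 is a 1.3-fold higher number from compound 1 to compound 3 (0.11 log units; within the scatter). Compound 3 is thus expected near 22000 nM, within 7000 nM to 70000 nM.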

Compound 3, half-maximal inhibitory concentration: 4550 nM
Compound 3: middle estimate off by 4.8-fold (0.68 log units), on the high side; the whole stated range lies above it.
By their numbers in this assay, from the lowest: compound 3; then compound 1; then compound 2.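

In this assay the position ortho to a methoxy group proves sensitive to a one-atom exchange: bromo in place of methyl gives a 3.8-fold lower number from compound 1 to compound 3 (0.57 log units; beyond the scatter) and so separates two groups of equal heavy-atom count, neither with a hydrogen-bond donor or acceptor. Changing the whole aryl pattern, with 3-bromo-4-methoxyphenyl in place of 4-chlorophenyl, gives a 130-fold lower number from compound 2 to compound 3 (2.12 log units; beyond the scatter) and widens the span of the series well beyond the effect of the methyl-to-bromo change alone. No measurement at hand explains the lower number seen with bromo.

From the compounds shown here alone, only methyl and bromo have been compared at this carbon with the methoxy group retained, so the reach of the trend remains unknown. Going by these compounds, how an amine, a carboxylic acid or a longer chain would read here also remains open.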